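Changing the ring-nitrogen substituent of compound 1

The compounds below may be only part of what the source reports. "The series", "measured", "known", "first", "only" and "open" are said of these compounds alone.

Among the compounds with values here, in a functional assay on SU-DHL-6 cells (Homo sapiens) for antiproliferative activity, read by MTT assay (a lower number here means a stronger inhibitor, a higher number a weaker inhibitor), compound 1 (`COc1ncc(-c2ccc3ncnc(N[C@H]4CCCN(C(=O)C5CCOCC5)C4)c3c2)cc1C#N`) gives 150 nM, the lower of the two numbers so far. Compound 2 (`COc1ncc(-c2ccc3ncnc(N[C@H]4CCCN(C(=O)C5CCN(C)CC5)C4)c3c2)cc1C#N`) gives 420 nM. Within the data shown here, the single measured step, a 2.8-fold higher number from compound 1 to compound 2 (0.45 log units; beyond the scatter), places 1-methylpiperidin-4-yl in place of oxan-4-yl on a carbonyl carbon and is modest.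

Compound 3 (`CCOC(=O)CN1CCC[C@H](Nc2ncnc3ccc(-c4cnc(OC)c(C#N)c4)cc23)C1`) has not yet been measured. It carries (ethoxycarbonyl)methyl in place of (oxan-4-yl)carbonyl on an amine nitrogen in a ring. The measured step bears on this change only loosely: it keeps the carbonyl on that nitrogen and alters only the group beyond it, whereas compound 3 replaces the whole substituent. Among the measured compounds shown here, no measured compound tests such a replacement, so the size of the step remains poorly constrained.

For the measured compounds named here, the one change made at this end of compound 1 gave a higher number, a 2.8-fold higher number from compound 1 to compound 2 (0.45 log units; beyond the scatter), and a step of similar or somewhat larger size in the same direction is expected. The estimated step is a 3.3-fold higher number from compound 1 to compound 3 (0.52 log units; beyond the scatter). Compound 3 is expected at 500 nM, with an estimated range of 170 nM to 1500 nM.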

Compound 3, half-maximal inhibitory concentration: 500 nM
For compound 3 middle estimate and measured number coincide at the digits printed; the range from low to high includes it.
By their numbers in this assay, from the lowest: compound 1; then compounds 2 and 3 (each within the scatter of the next).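

In this assay, replacing the whole (oxan-4-yl)carbonyl with (ethoxycarbonyl)methyl gives a 3.3-fold higher number from compound 1 to compound 3 (0.52 log units; beyond the scatter), so a substituent with no ring and no carbonyl directly on the amine nitrogen in a ring still leaves compound 3 in the same range as compound 2. That match is close: a 1.2-fold higher number from compound 2 to compound 3 (0.08 log units; within the scatter), so compound 2 and compound 3 cannot be told apart in this assay, even though compound 2 keeps both a ring and the carbonyl on that nitrogen. No measurement on these compounds accounts for this match or for the separation of compound 1 from the other two.

From the compounds shown here alone, the ring and the linking carbonyl change together from compound 1 to compound 3, so the share of each in the step remains open, as does whether the ester itself matters. An oxan-4-yl ring joined to the nitrogen through a methylene, a carboxylic acid in place of the ethyl ester, or a longer chain carrying the ester would each test one of these features separately.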